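Cytotoxicity of a methylenecyclopropane nucleoside and its ring epimer

The compounds below may be only part of what the source reports. "The series", "measured", "known", "first", "only" and "open" are said of these compounds alone.

Compound 1 `Nc1ncnc2c1ncn2/C=C1/C[C@@H]1[C@@H](O)CO` was examined in an ADME assay on Akata cells (Homo sapiens) for cytotoxicity (a higher number here means that more compound is tolerated, a lower number that less compound is tolerated), where compound 1 gives 55000 nM. Its companion compound 2 `Nc1nc2c(ncn2/C=C2\C[C@H]2[C@H](O)CO)c(=O)[nH]1` gives 86600 nM in this assay, and the two values lie within the scatter of each other, so neither stands apart. Compound 3 `Nc1ncnc2c1ncn2/C=C1/C[C@H]1[C@@H](O)CO` has not yet been measured in this assay. Compared with compound 1, (the two compounds have the same atoms and bonds and differ only in configuration as drawn: 1 of 3 stereo elements differ; a stereocentre at a saturated ring carbon is drawn S in compound 1 and R in compound 3). Within the data shown here, with no step between measured compounds to draw on, the change is expected to move the value of compound 3 by no more than the scatter, so the step from compound 1 to compound 3 is estimated as no change at the digits printed from compound 1 to compound 3 (within the scatter). Compound 3 is therefore expected to give about 55000 nM, between 25000 nM and 120000 nM.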

Compound 3, half-maximal cytotoxic concentration: 61500 nM
Beside the measured number, compound 3's estimate is 1.1-fold (0.05 log units) below it; measured number inside the range.
By their numbers in this assay, from the lowest: compounds 1, 3 and 2 (each within the scatter of the next).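

The earlier compounds shown here offered no step to read, and this assay now gives one: a 1.1-fold higher number from compound 1 to compound 3 (0.05 log units; within the scatter). Drawing this saturated ring carbon S or R therefore leaves the number within the scatter, so this change of configuration alone does not set the two compounds apart here. The comparison is confined to that single stereocentre: the fact that compounds 1 and 3 differ only in the configuration as drawn

The compounds shown leave open whether changing the configuration at the other stereo elements would do the same. They also leave open whether an amine or a carboxylic acid on the shared core would move the number beyond the scatter.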